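Methyl to Methoxy: One Step in an Antiproliferative Series

The source may report more compounds than this note shows. Statements on the series, on what has been measured and on what is new or still open speak of the compounds shown alone.

Compound 1 `Nc1ccccc1NC(=O)c1ccc(COc2ccc(Br)cc2)cc1`: > 32000 nM (a limit)
Compound 2 `Cc1ccc(OCc2ccc(C(=O)Nc3ccccc3N)cc2)cc1`: 4860 nM

Within the data shown here, in a functional assay on HCT-116 cells (Homo sapiens) for antiproliferative activity, read by CCK-8 assay, with a stated time of 72 h (a higher number here means a weaker inhibitor, a lower number a stronger inhibitor), compound 2 gives 4860 nM, the only actual number in this small set. Compound 1 is reported only as a limit, > 32000 nM.

Compound 3 `COc1ccc(OCc2ccc(C(=O)Nc3ccccc3N)cc2)cc1` has not yet been measured. It differs from compound 2 by methoxy in place of methyl on an aromatic carbon, para to a large group: methoxy in place of methyl on an aromatic carbon.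

Among the measured compounds shown here, only one measured step bears on this change, and it concerns the same substituent: an at least 6.5-fold lower number from compound 1 to compound 2 (0.81 log units; beyond the scatter), with methyl in place of bromo. That step shows that a change here can go beyond the scatter, but it involves no methoxy and gives no direction for one. No clear step beyond the scatter is therefore expected in this assay.

The expected size is a 1.2-fold lower number from compound 2 to compound 3 (0.08 log units; within the scatter). For compound 3 the estimate is 4000 nM, with an expected range from 1400 nM to 14000 nM.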

Compound 3, half-maximal inhibitory concentration: 2020 nM
Estimate against measurement, compound 3: 2.0-fold (0.30 log units) above; low and high end bracket the measured number.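

In this assay, among these compounds, the change from 4-methylphenyl to 4-methoxyphenyl gives a 2.4-fold lower number from compound 2 to compound 3 (0.38 log units; beyond the scatter), which supplies the direction for methoxy at this position that the earlier compounds could not give. Set against bromo in the same place, methoxy gives an at least 15-fold lower number from compound 1 to compound 3 (1.19 log units; beyond the scatter), so the three substituents now fall in a single order in this assay, with methoxy giving the lowest number and bromo the highest. The size of that second step is open-ended, as compound 1 is known only as a limit: the limit of > 32000 nM in this assay, at which 1 of the 3 values shown sits.

From the compounds shown here alone, whether an amine, a hydroxyl or a longer chain such as ethoxy in the same place would lower the number further remains open. So does whether this order of methoxy, methyl and bromo holds in any other cell line.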